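Extending a Chain on Two Different Cores

The source may report more compounds than this note shows. Statements on the series, on what has been measured and on what is new or still open speak of the compounds shown alone.

Compound 1 `CCCCC(=O)NN(C(=O)c1cc(C)cc(C)c1)C(C)(C)C` and compound 2 `CCCCCCCC(=O)NN(C(=O)c1cc(C)cc(C)c1)C(C)(C)C` share one core and differ only by propyl in place of hydrogen on a saturated chain carbon, four bonds along the chain from a carbonyl carbon. In an assay on cells for agonist activity at ecdysone receptor (Bombyx mori), read by a luciferase reporter, with a stated time of 24 h (a lower number here means that less compound is needed, a higher number that more compound is needed for the effect), compound 1 gives 1860 nM, and compound 2 gives 97.7 nM. Put together, this is a 19-fold lower number from compound 1 to compound 2 (1.28 log units; beyond the scatter).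

Compound 3 `CN(NC(=O)c1ccccc1)C(=O)c1ccccc1` is built on a different core; how its core differs from that of compound 1 is not broken down here. In this assay compound 3 reaches only a limit of the assay, > 100000 nM, so no number for it is known. That places compound 3 at the limit of > 100000 nM in this assay, at which 1 of the 3 values shown sits.

Compound 4 `CCCCN(NC(=O)c1ccccc1)C(=O)c1ccccc1`, not yet measured, differs from compound 3 by propyl in place of hydrogen on a saturated chain carbon bound to an amide-type nitrogen. For the measured compounds named here, this is the same kind of change as the one between compound 1 and compound 2, but the place is not the same: in the first pair the propyl enters on a saturated chain carbon, four bonds along the chain from a carbonyl carbon, while here it enters on a saturated chain carbon bound to an amide-type nitrogen.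

Because compound 3 sits at a limit, the starting point for compound 4 is uncertain, and the guide is the lowering seen in a 19-fold lower number from compound 1 to compound 2 (1.28 log units; beyond the scatter) on the other core. Compound 4 is therefore expected to give about 40000 nM in this assay, plausibly between 5000 nM and 150000 nM. That estimate implies an expected step of an at least 2.5-fold lower number from compound 3 to compound 4 (0.39 log units; beyond the scatter), with a real chance that only a limit is reported again.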

Compound 4, half-maximal effective concentration: 7080 nM
Compound 4: the middle estimate sits 5.6-fold (0.75 log units) above what was measured; the range from low to high includes it.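

In this assay, propyl in place of hydrogen on a saturated chain carbon bound to an amide-type nitrogen gives an at least 14-fold lower number from compound 3 to compound 4 (1.14 log units; beyond the scatter), so this core also shows a large lowering of the number. Set beside the earlier step, which arose at a different place on a different core, the result reads: the same change on two cores in this assay, a 19-fold lower number (1.28 log units; beyond the scatter) from compound 1 to compound 2 and an at least 14-fold lower number (1.14 log units; beyond the scatter) from compound 3 to compound 4; the limit leaves it open whether they differ. Compound 3 stands at a limit of the assay, > 100000 nM, so the second step has no exact size; the two pairs show the same direction on both cores, but they do not show that the size of the step carries over, and two pairs are too few to make a general rule for the series.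

The compounds shown leave open how the number in this assay follows chain length at the amide-type nitrogen, for example with an ethyl group or a chain longer than butyl. They also leave open whether a group of another kind at that place, such as benzyl or a chain ending in an amine or a carboxylic acid, would lower the number as the butyl chain of compound 4 does.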